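Dichlorophenyl in Place of Fluorophenyl on the Triazole Nitrogen

The compounds below may be only part of what the source reports. "The series", "measured", "known", "first", "only" and "open" are said of these compounds alone.

Compound 3 `Oc1cc(C(F)(F)F)ccc1-c1nc(-c2ccccc2O)n(-c2ccccc2F)n1` stands second highest of three in a functional assay on PC-12 cells (Rattus norvegicus) for cytotoxicity, read by MTT assay, with stated times of 2 h and 24 h, tested at 5 uM (a higher number here means a stronger effect of the compound at the concentration tested, a lower number a weaker effect), where compound 3 gives 86.6%. Its neighbours are compound 2 `Oc1cc(C(F)(F)F)ccc1-c1nc(-c2ccccc2O)n(-c2ccc(I)cc2)n1`, which gives 94.4%, and compound 1 `CC(C)(C)c1ccc(-n2nc(-c3ccc(C(F)(F)F)cc3O)nc2-c2ccccc2O)cc1`, which gives 77.8%. The steps touching the aryl group on the aromatic nitrogen are small: a number 7.8 percentage points lower from compound 2 to compound 3 (within the scatter) and a number 8.8 percentage points higher from compound 1 to compound 3 (within the scatter). Only a number 16.6 percentage points higher from compound 1 to compound 2 (beyond the scatter) lies beyond the scatter. Compound 4 `Oc1cc(C(F)(F)F)ccc1-c1nc(-c2ccccc2O)n(-c2ccc(Cl)cc2Cl)n1` differs from compound 3 in one place: 2,4-dichlorophenyl in place of 2-fluorophenyl on an aromatic nitrogen. Since both measured swaps of this aryl group stayed within the scatter, the author expects no step beyond the scatter, with at most a slight rise, as a number 1.4 percentage points higher from compound 3 to compound 4 (within the scatter). Compound 4 is therefore estimated at 88%, between 76% and 97%.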

Compound 4, a percentage reported as activity, at one concentration (the size of the read-out at that concentration, not a potency): 86.7%
The estimate for compound 4 lay 1.3 percentage points above the measured number; the range from low to high includes it.
By their numbers in this assay, from the lowest: compounds 1, 3, 4 and 2 (each within the scatter of the next, the first and the last beyond it).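

In this assay, compound 4 carries two chlorine atoms where compound 3 carries one fluorine, yet the numbers do not separate, with a number 0.1 percentage points higher from compound 3 to compound 4 (within the scatter). The swaps from the other two aryl groups also stay within the scatter, with a number 7.7 percentage points lower from compound 2 to compound 4 (within the scatter) and a number 8.9 percentage points higher from compound 1 to compound 4 (within the scatter), so 2,4-dichlorophenyl lies within the scatter of both 4-iodophenyl and 4-(tert-butyl)phenyl, though those two lie beyond it from each other.

Going by these compounds, whether an amine or a carboxylic acid on this aryl ring, or cyclohexyl in its place on the nitrogen, would give a step beyond the scatter stays open. No measurement given here bears on what lies behind these numbers.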